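Benzyl in Place of Chlorophenyl on a Triazole Ring

A few compounds are considered here, and "the series" means these few. Any claim that something is new, unique, unknown or untested is made for them only; others in the source may bear on it.

Three compounds share a triazole ring that carries either a 4-chlorophenyl or a benzyl group. Compound 3 `O=c1nc2oc(CCCCl)c(C#CCCCCl)c2cn1Cc1cn(-c2ccc(Cl)cc2)nn1` was tested in a functional assay on HeLa cells (Homo sapiens) for antiproliferative activity, read by MTT assay, with a stated time of 72 h; on this read-out lower numbers stand for stronger inhibition and higher numbers for weaker inhibition; its result, > 100000 nM, is a limit of the assay rather than a number. Compound 1 `O=c1nc2oc(CCCCl)c(C#CCCCCl)c2cn1Cc1cn(Cc2ccccc2)nn1` gives 25400 nM in this assay. Between the two, the only change is benzyl in place of 4-chlorophenyl on an aromatic nitrogen, and it made the step of an at least 3.9-fold lower number from compound 3 to compound 1 (0.59 log units; beyond the scatter). Compound 2 `O=c1nc2oc(C3CC3)cc2cn1Cc1cn(-c2ccc(Cl)cc2)nn1` also reaches only a limit in this assay, > 100000 nM. How the core of compound 2 differs from that of compound 3 is not broken down here. Compound 4 `O=c1nc2oc(C3CC3)cc2cn1Cc1cn(Cc2ccccc2)nn1` is not yet measured; it differs from compound 2 by benzyl in place of 4-chlorophenyl on an aromatic nitrogen, the same change as that between compound 3 and compound 1, at the same place. Two of the three results sit at the limit of > 100000 nM in this assay, at which 2 of the 3 values shown sit, so the measured step is known only as a lower bound. The step of an at least 2.0-fold lower number from compound 2 to compound 4 (0.30 log units; that floor lies within the scatter) is expected, resting on an at least 3.9-fold lower number from compound 3 to compound 1 (0.59 log units; beyond the scatter). Compound 4 is therefore estimated at 50000 nM, with a likely range from 15000 nM to 200000 nM.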

Compound 4, half-maximal inhibitory concentration: 50000 nM
The estimate for compound 4 equals the measured number at the digits printed, within the range that was stated.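

In this assay, putting benzyl in place of 4-chlorophenyl on the core of compound 2 gives an at least 2.0-fold lower number from compound 2 to compound 4 (0.30 log units; that floor lies within the scatter). The change therefore points the same way on both cores, although only the step on the core of compound 1 has a floor beyond the scatter, and the two steps cannot be told apart: the same change on two cores in this assay, an at least 3.9-fold lower number (0.59 log units; beyond the scatter) from compound 3 to compound 1 and an at least 2.0-fold lower number (0.30 log units; that floor lies within the scatter) from compound 2 to compound 4; the limit leaves it open whether they differ The true size of the change on either core remains unknown, because compound 2 and compound 3 each give a limit of the assay rather than a number: the limit of > 100000 nM in this assay, at which 2 of the 4 values shown sit.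

The compounds shown leave open whether the result follows from losing the chlorine or from gaining the extra carbon of the benzyl group, a question that a plain phenyl or a 4-chlorobenzyl group on the triazole nitrogen could help to separate. From the compounds shown here alone, it also remains open how a longer chain, such as phenethyl, or an amine on the benzyl ring would fare on these two cores.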